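This account rests on a few compounds, and the source may have more. Where it says the series, first, only, none or still open, it means among the compounds named here.

In a functional assay on COLO 205 cells (Homo sapiens) for antiproliferative activity, read by MTT assay (a lower number here means a stronger inhibitor, a higher number a weaker inhibitor), three compounds have been measured so far:

compound 1 `COc1ccc2nc(N(Cc3cc(-c4ccc(SC(F)(F)F)cc4)no3)c3nc4ccc(F)cc4s3)sc2c1`: 11100 nM
compound 2 `COc1ccc2nc(N(Cc3cc(-c4ccc(OC(F)(F)F)cc4)no3)c3nc4ccc(F)cc4s3)sc2c1`: 9940 nM
compound 3 `FC(F)(F)Sc1ccc(-c2cc(CN(c3ncccn3)c3nc4ccccc4s3)on2)cc1`: 10100 nM

Compound 1 and compound 2 share the same core and differ in one place only: trifluoromethoxy in place of (trifluoromethyl)sulfanyl on an aromatic carbon. That change gave a step of a 1.1-fold lower number from compound 1 to compound 2 (0.05 log units; within the scatter), so within this pair the two groups behave alike as far as this assay can tell.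

Compound 3 carries a different core. How the core of compound 3 differs from the core of compound 1 is not broken down here. Whatever that difference is, the values of compound 1, compound 2 and compound 3 all sit within the usual scatter of one another, so none of the three can be called stronger or weaker than another.

Compound 4 `FC(F)(F)Oc1ccc(-c2cc(CN(c3ncccn3)c3nc4ccccc4s3)on2)cc1` has not yet been measured. It stands to compound 3 exactly as compound 2 stands to compound 1: trifluoromethoxy in place of (trifluoromethyl)sulfanyl on an aromatic carbon. The place of the change is described in identical words in both pairs, so this is the same change, made on a different core. Among the measured compounds shown here, the only guide to its effect is the step of a 1.1-fold lower number from compound 1 to compound 2 (0.05 log units; within the scatter), which was too small to count as a change. The step from compound 3 to compound 4 is therefore expected to be small as well, estimated at a 1.1-fold lower number from compound 3 to compound 4 (0.03 log units; within the scatter). Compound 4 is expected to give about 9500 nM in this assay, most likely falling between 4800 nM and 19000 nM.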

Compound 4, half-maximal inhibitory concentration: 5690 nM
For compound 4 the middle estimate is 1.7-fold (0.22 log units) above the measured one; the measured number falls inside the stated range.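

Carrying the change over to the core of compound 3, with trifluoromethoxy in place of (trifluoromethyl)sulfanyl, gave a 1.8-fold lower number from compound 3 to compound 4 (0.25 log units; within the scatter) in this assay, so compound 3 and compound 4 cannot be told apart in this test. The exchange therefore carries over without any detectable difference between the two cores, as the two steps agree as closely as measurements of this kind can show: the same change on two cores in this assay, a 1.1-fold lower number (0.05 log units; within the scatter) from compound 1 to compound 2 and a 1.8-fold lower number (0.25 log units; within the scatter) from compound 3 to compound 4, 1.6-fold (0.20 log units) apart, within the scatter of two such steps

Among the compounds shown here, this shows only that the two groups could be exchanged on these two cores without a change large enough to read; it does not show that either group is the better choice, that the same would hold on a third core, or that the two steps are truly identical, since a small real difference could hide inside the scatter.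

The compounds shown leave open whether the number moves at all when something quite unlike these two groups, such as an amine, a carboxylic acid or a longer alkyl chain, sits on that aromatic carbon. They also leave open which parts of the cores matter, since the core of compound 1 and the core of compound 3 differ in ways not separated here.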